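Pyrrolidine-bearing bicyclic nitriles: paw edema inhibition notes

The compounds below may be only part of what the source reports. "The series", "measured", "known", "first", "only" and "open" are said of these compounds alone.

Measured so far:
compound 1 `N#CC1=C(/N=C/Nc2ccc([N+](=O)[O-])cc2)N(c2ccccc2)C(=O)N2CCCCC(N3CCCC3)C12` gives 41.5% in a functional assay on the whole organism (strain albino) for inhibition, with Rattus norvegicus as the target, read by paw edema, with stated times of 1 h and 2 h, at a dose of 20 mmol/kg by the intraperitoneal route; a higher number here means more inhibition at the dose given (going by the name of the read-out), a lower number less inhibition
compound 2 `COc1ccc(N/C=N/C2=C(C#N)C3C(N4CCCC4)CCCCN3C(=O)N2c2ccccc2)cc1` gives 37.2% in this assay

For the measured compounds named here, compound 2 and compound 1 sit within the scatter of each other in this assay; the only measured step, a number 4.3 percentage points lower from compound 1 to compound 2 (within the scatter), changes nothing beyond the scatter. Compound 3 `N#CC1=C(N)N(c2ccccc2)C(=O)N2CCCCC(N3CCCC3)C12` differs from compound 2 by one nitrogen atom in place of a group of 11 heavy atoms (8 carbon, 2 nitrogen, 1 oxygen; one six-membered aromatic ring of carbon only), on a double-bonded ring carbon. Going by the values given here, no measured step bears on this change, so the expectation for compound 3 rests on the two numbers alone and is loosely held. The estimated step of a number 5.2 percentage points lower from compound 2 to compound 3 (within the scatter) is expected to stay within the scatter. For compound 3 the estimate is 32%, expected within 10% to 52%.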

Compound 3, a percentage reported as inhibition, in the whole organism at one dose (the size of the read-out at that dose, not a potency): 86.9%
The estimate for compound 3 lay 54.9 percentage points below the measured number, outside the stated range (above it).
By their numbers in this assay, from the lowest: compounds 2 and 1 (each within the scatter of the next); then compound 3.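

At this double-bonded ring carbon, amino in place of the whole aromatic side group gives a large change in this assay: a number 49.7 percentage points higher from compound 2 to compound 3 (beyond the scatter), and a number 45.4 percentage points higher from compound 1 to compound 3 (beyond the scatter). The methoxy for nitro change on the aromatic carbon had shown nothing beyond the scatter, so this position responds to the replacement of the whole group in a way that change did not reveal. Nothing at hand accounts for the rise.

Open, as far as these compounds go, is whether the free amino itself matters, or only the loss of the larger group: methylamino or acetylamino at this carbon would bear on that.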